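This account rests on a few compounds, and the source may have more. Where it says the series, first, only, none or still open, it means among the compounds named here.

Measured so far in a functional assay on HEL cells (Homo sapiens) for cytotoxicity; on this read-out higher numbers stand for lower toxicity in this test and lower numbers for higher toxicity in this test:
- compound 1 `CCCCC#Cc1cc2cn([C@@H]3O[C@H](CO)[C@@H](O)[C@H]3O)c(=O)nc2o1`: > 144000 nM, a limit
- compound 2 `CCCCCCCCCCC#Cc1cc2cn([C@@H]3O[C@H](CO)[C@@H](O)[C@@H]3O)c(=O)nc2o1`: 116000 nM
- compound 3 `CCCCC#Cc1cc2cn([C@H]3C[C@H](O)[C@@H](CO)O3)c(=O)nc2o1`: > 150000 nM, a limit

Not yet measured: compound 4 `CCCCC#Cc1cc2cn([C@@H]3O[C@H](CO)[C@@H](O)[C@@H]3O)c(=O)nc2o1`.

Compound 3 has only a limit, > 150000 nM. Compound 1 also has only a limit, > 144000 nM. Compound 2 is the only one of the three with a numeric value, 116000 nM.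

The change under consideration is hydroxy in place of hydrogen on a saturated ring carbon. Within the data shown here, one measured step bears on it: a step that the two limits leave unreadable from compound 1 to compound 3. This step runs the opposite way, with hydrogen in place of hydroxy on a saturated ring carbon, and it gives no size to carry over. Both of its ends remain limits, so it shows no toxicity that appears or disappears with this exchange.

In this assay, no step beyond the usual scatter is therefore expected, and no direction can be assigned. The estimated step is an at least 1.0-fold lower number from compound 3 to compound 4 (0.01 log units; that floor lies within the scatter). A limit is the most likely kind of result for compound 4, as it was for compound 1 at > 144000 nM.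

Compound 4 is estimated at 144000 nM, with an expected range from 70000 nM to 250000 nM.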

Compound 4, half-maximal cytotoxic concentration: > 144000 nM
Compound 4: no number, only a limit (the forecaster's own chance of this, stated with the estimate: 75%); the middle value sits exactly at the limit.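

In this assay compound 4 also gives only a limit, > 144000 nM. Among these compounds, the steps to compound 4 from compound 3 and from compound 1 cannot be read, so neither hydroxy in place of hydrogen on this saturated ring carbon nor the change in configuration as drawn yields a number here, and the same limit recurs: the limit of > 144000 nM in this assay, at which 2 of the 4 values shown sit. The one readable step is an at least 1.2-fold higher number from compound 2 to compound 4 (0.09 log units; that floor lies within the scatter), with hydrogen in place of hexyl on a saturated chain carbon, and it gives no evidence of a real difference between the two chain lengths.

The compounds shown leave open how far the toxicity of compounds 1, 3 and 4 lies beyond their limits, and so whether hydroxy on this ring carbon or its configuration has any effect at all in this assay. Also open, from the compounds shown here alone, is what an amine or a fluorine on this ring carbon would do, and whether hydroxy in place of hydrogen or a change of configuration there would give a readable step on the longer chain of compound 2.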